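One ring swap on the shared core: expected cytotoxicity

This account rests on a few compounds, and the source may have more. Where it says the series, first, only, none or still open, it means among the compounds named here.

Compound 1 `Cc1ccc2c(NCc3ccc(NC(=O)C4CCN(Cc5ccccc5)CC4)cc3)nc(N3CCCCCC3)nc2c1` — in a functional assay on SV5A8 cells (Homo sapiens) for cytotoxicity (on this read-out lower numbers stand for stronger inhibition and higher numbers for weaker inhibition), compound 1 gives > 6880 nM.
Compound 2 `Cc1ccc2c(NCc3ccc(NC(=O)C4CCN(Cc5ccccc5)CC4)cc3)nc(N3CCC(N4CCCC4)CC3)nc2c1` — in this assay compound 2 gives > 8090 nM.
Compound 3 `Cc1ccc2c(NCc3ccc(NC(=O)C4CCN(Cc5ncc[nH]5)CC4)cc3)nc(N(C)C)nc2c1` — in this assay compound 3 gives > 20000 nM.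

None of the three values is a number; each is a limit of the assay. The step that the two limits leave unreadable from compound 1 to compound 2 therefore cannot be read. Compound 3 sits at the limit (the limit of > 20000 nM in this assay, at which 1 of the 3 values shown sits), the highest of the three limits, so its standing among the measured compounds is only a range that reaches beyond the other two.

Compound 4 `Cc1ccc2c(NCc3ccc(NC(=O)C4CCN(Cc5ccccc5F)CC4)cc3)nc(N(C)C)nc2c1` differs from compound 3 in a single place: 2-fluorophenyl in place of 1H-imidazol-2-yl on a saturated chain carbon bound to an amine nitrogen in a ring. Among the measured compounds shown here, no measured pair shows this change, or any change at that position, so no measured step bears on it; the only pair that differs in one place lies elsewhere on the core and is itself unreadable. In this assay the expectation for compound 4 can rest only on where compound 3 stands, and the step of an at least 1.1-fold lower number from compound 3 to compound 4 (0.04 log units; that floor lies within the scatter) is expected to be none beyond the scatter. Compound 4 is estimated at 18000 nM, with a range from 5000 nM to 60000 nM, and most likely the assay again reports only a limit.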

Compound 4, half-maximal inhibitory concentration: > 6670 nM
Compound 4 was reported as a limit; the forecaster's own chance of this, stated with the estimate: 70%; the middle value does not contradict the limit.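

In this assay, compound 3 and compound 4 are both reported only as limits, so the step between them cannot be read. The compounds shown leave open where any of them truly stands, and whether 2-fluorophenyl in place of 1H-imidazol-2-yl changes the read-out at all.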